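Carbonyl added to the pyrrolidine ring of the series

This account rests on a few compounds, and the source may have more. Where it says the series, first, only, none or still open, it means among the compounds named here.

Compound 2 `Cc1cc(N2CCCC2)c2ncc(CSCCc3ccccc3)n2c1` is judged in an ADME assay on HEL cells (Homo sapiens) for cytotoxicity, with a stated time of 3 days; on this read-out higher numbers stand for lower toxicity in this test and lower numbers for higher toxicity in this test. In this assay compound 2 gives > 100 ug/mL, a limit of the assay rather than a number. Among the measured compounds shown here, compound 1 `Cc1cc(-c2ccoc2)c2ncc(CSCCc3ccccc3)n2c1` is the only other measured compound, and in this assay compound 1 gives 100 ug/mL. For the measured compounds named here, the single measured step, a number no lower from compound 1 to compound 2 (the limit leaves the size open), ends at the limit of > 100 ug/mL in this assay, at which 1 of the 2 values shown sits, so its size stays open. Compound 3 `Cc1cc(N2CCCC2=O)c2ncc(CSCCc3ccccc3)n2c1` differs from compound 2 by 2-oxopyrrolidin-1-yl in place of pyrrolidin-1-yl on an aromatic carbon. Going by the values given here, no measured step covers this change; the one step known touches the same position and shows no drop. For compound 3 the expected step is a number no higher from compound 2 to compound 3 (the limit leaves the size open), none beyond the scatter. Compound 3 is therefore estimated at 100 ug/mL, between 40 ug/mL and 100 ug/mL, with a fair chance that only a limit is reported again.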

Compound 3, minimum cytotoxic concentration: 20 ug/mL
Estimate against measurement, compound 3: 5.0-fold (0.70 log units) above; measured number below the stated range.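

In this assay this position proves sensitive to a single added carbonyl on the pyrrolidine ring, with an at least 5.0-fold lower number from compound 2 to compound 3 (0.69 log units; beyond the scatter). Against the furan-3-yl group, the 2-oxopyrrolidin-1-yl group gives a 5.0-fold lower number from compound 1 to compound 3 (0.70 log units; beyond the scatter), leaving compound 3 the most toxic of the three in this test. The first step has only a lower bound on its size because compound 2 sits at a limit of the assay: the limit of > 100 ug/mL in this assay, at which 1 of the 3 values shown sits.

Still open, as far as these compounds go, is whether the drop is tied to the five-membered lactam or would also follow an open-chain acetamide at this position. A piperidin-2-one ring there would test the same question.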